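The compounds below may be only part of what the source reports. "The series", "measured", "known", "first", "only" and "open" are said of these compounds alone.

Measured compounds:
compound 1, `CCCS(=O)(=O)Nc1ccc(Cl)c(C(=O)Nc2cnc3[nH]nc(OC)c3c2)c1F` — 1 mL/min/kg
compound 2, `CCCS(=O)(=O)Nc1ccc(F)c(C(=O)Nc2cnc3[nH]cc(Br)c3c2)c1F` — 7.2 mL/min/kg

In an in vivo ADME assay on the whole organism (strain CD-1) for pharmacokinetics, with Mus musculus as the target (a higher number here means faster removal of the compound, a lower number slower removal), compound 1 gives 1 mL/min/kg, the lowest of the two numbers recorded. Compound 2 gives 7.2 mL/min/kg in this assay; the two values show a gap beyond the scatter of repeated measurements, with compound 1 the more slowly removed of the pair. Among the measured compounds shown here, no step between measured compounds that differ in a single place has been recorded, so nothing measured tracks the change in question directly.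

Compound 3, `CCCS(=O)(=O)Nc1ccc(Cl)c(C(=O)Nc2cnc3[nH]ncc3c2)c1F`, differs from compound 1 in one place: hydrogen in place of methoxy on an aromatic carbon. The methoxy leaves and a hydrogen enters, on an aromatic carbon of a five-membered aromatic ring with 2 nitrogen within a fused system of two rings. For the measured compounds named here, with no measured pair showing this change, the expectation rests on compound 1 alone. The expected step, a 1.6-fold higher number from compound 1 to compound 3 (0.20 log units; within the scatter), is small and upward, close to the scatter. Compound 3 is expected to give 1.6 mL/min/kg in this assay, within a range from 0.6 mL/min/kg to 4.5 mL/min/kg.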

Compound 3, clearance in the Mus musculus assay: 2.3 mL/min/kg
The estimate for compound 3 lay 1.4-fold (0.16 log units) below the measured number; the measured number falls inside the stated range.
By their numbers in the Mus musculus assay, from the lowest: compound 1; then compound 3; then compound 2.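

Hydrogen in place of methoxy on an aromatic carbon of the five-membered aromatic ring now has a measured step of its own, and in the Mus musculus assay the change is not silent: a 2.3-fold higher number from compound 1 to compound 3 (0.36 log units; beyond the scatter). In a physicochemical assay for solubility, read by HPLC, in phosphate buffer, with a stated time of 24 h, at pH 7.4 (a higher number here means a more soluble compound, a lower number a less soluble compound), compound 1 gives 2 ug/mL and compound 3 gives 48 ug/mL. The same single change therefore moves removal modestly but the physicochemical assay by a large step, so at this position the loss of methoxy costs little in removal and is tied to a much more soluble compound: the measured solubility of compound 1, 2 ug/mL, and of compound 3, 48 ug/mL, a 24-fold higher number (1.38 log units; beyond the scatter)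

From the compounds shown here alone, all of this rests on one pair, so it remains open whether the two read-outs would also part in this way on another core. Going by these compounds, it is equally open how an amine or a longer alkoxy chain such as ethoxy at this position would fall between hydrogen and methoxy in either assay.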